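The source may report more compounds than this note shows. Statements on the series, on what has been measured and on what is new or still open speak of the compounds shown alone.

Measured so far in an ADME assay on HOS cells (Homo sapiens) for cytotoxicity; a higher number here means a weaker inhibitor, a lower number a stronger inhibitor:
- compound 1 `O=C1c2c(ccc(O)c2O)CN1Cc1ccccc1`: "not determined" (no result reported)
- compound 2 `O=C1c2ccc(O)c(O)c2C(=O)N1Cc1ccccc1`: "not determined" (no result reported)
- compound 3 `O=C1c2c(ccc(O)c2O)CN1Cc1cccc(F)c1`: 8600 nM

Among the compounds with values here, compound 3 gives the only number so far, 8600 nM. With no result reported for compound 1 and compound 2, it cannot be ranked against either of them, and this assay offers no spread of values to place it in.

The next compound to be tested is compound 4 `O=C1c2c(ccc(O)c2O)CN1Cc1cccc(Br)c1`. It keeps the shared core and the benzyl frame of compound 3 and changes one substituent: bromo in place of fluoro on an aromatic carbon. In words, this is bromo in place of fluoro on an aromatic carbon.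

Within the data shown here, no pair of measured compounds differs at a single place, so the series gives no direct guide to the size or direction of this step. The working expectation therefore stays close to compound 3 at 8600 nM, with only a slight lean towards a lower number. The expected change is a 1.2-fold lower number from compound 3 to compound 4 (0.09 log units; within the scatter), which may well not exceed the usual scatter.

For compound 4 the estimated value is 7000 nM, with an expected range from 2500 nM to 20000 nM.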

Compound 4, half-maximal inhibitory concentration: 7240 nM
Compound 4: the middle estimate sits 1.0-fold (0.01 log units) below what was measured; measured number inside the range.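

In this assay, the series now has its first pair differing in one place, and it gives a 1.2-fold lower number from compound 3 to compound 4 (0.07 log units; within the scatter) for bromo in place of fluoro on an aromatic carbon, meta to a large group. Within the data shown here, the two values cannot be told apart, so at this position this exchange of one halogen for the other gives no readable difference in this read-out, a point that the single value of compound 3 could not show. No measurement shown gives a reason for this result.

On these data alone, with compound 1 at "not determined" (no result reported) and compound 2 at "not determined" (no result reported), steps to either of them cannot be read, and whether having a halogen on this carbon matters at all stays open. Also open, as far as these compounds go, is how, in this assay, a methoxy group, an amine or a carboxylic acid on this same carbon would read, since the two halogens alone cover only a narrow part of what this position could carry.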